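The compounds below may be only part of what the source reports. "The series", "measured", "known", "first", "only" and "open" are said of these compounds alone.

Measured in an ADME assay on HEK293 cells for agonist activity at Toll-like receptor 8 (Homo sapiens), read by a luciferase reporter, with a stated time of 6 h; on this read-out higher numbers stand for an effect only at larger amounts of compound and lower numbers for an effect already at smaller amounts:
compound 1 `CNc1nc(N)nc2ccccc12`: 6.87 uM
compound 2 `CCCCCNc1nc(N)nc2ccccc12`: 0.1 uM

For the measured compounds named here, compound 2 holds the lowest of the two numbers in this assay; the single measured step is a 69-fold lower number from compound 1 to compound 2 (1.84 log units; beyond the scatter), the only one available. Compound 3 `COCCCNc1nc(N)nc2ccccc12` differs from compound 2 as methoxy in place of ethyl on a saturated chain carbon, three bonds along the chain from a nitrogen on an aromatic ring, read one bond further out as pentyl to 3-methoxypropyl. Going by the values given here, the measured step shows that the chain on the ring nitrogen carries most of the activity, but no step tests an oxygen within that chain, so its effect is untested. Compound 3 is expected to keep the chain length and therefore most of the activity, with a modest rise in the number, a 3.0-fold higher number from compound 2 to compound 3 (0.48 log units; beyond the scatter), estimated at 0.3 uM (range 0.08 uM to 1.2 uM).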

Compound 3, minimum effective concentration: 0.01 uM
Compound 3: middle estimate off by 30-fold (1.48 log units), on the high side, and the stated range ends above it.
By their numbers in this assay, from the lowest: compound 3; then compound 2; then compound 1.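

In this assay, methoxy in place of ethyl, three bonds along the chain from a nitrogen on an aromatic ring, gives a 10-fold lower number from compound 2 to compound 3 (1.00 log units; beyond the scatter), so an oxygen at this position is tolerated and the number falls further. Over the whole chain the step is a 690-fold lower number from compound 1 to compound 3 (2.84 log units; beyond the scatter), larger than the step to the pentyl chain of compound 2. Nothing available explains the gain.

From the compounds shown here alone, whether a hydroxyl, an amine or a longer chain at this place would hold the number remains open. So does whether the oxygen must sit at exactly this point along the chain.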